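A few compounds are considered here, and "the series" means these few. Any claim that something is new, unique, unknown or untested is made for them only; others in the source may bear on it.

Compound 2 `CN(CCCN1CCN(c2ccccc2)CC1)c1cccc(O)c1` gives the lowest of the two numbers recorded in an assay on HEK293 cells for displacement of a labelled ligand from 5-hydroxytryptamine receptor 7 (Homo sapiens), read by scintillation counting, with a stated time of 30 min (on this read-out higher numbers stand for weaker inhibition and lower numbers for stronger inhibition), where compound 2 gives 20 nM. Its nearest neighbour is compound 1 `CN(CCCN1CCN(c2ccccc2)CC1)c1cccc(Cl)c1`, which in this assay gives 179 nM; the step of a 9.0-fold lower number from compound 1 to compound 2 (0.95 log units; beyond the scatter) is the hydroxy in place of chloro on an aromatic carbon.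

Compound 3 `Oc1cccc(N(CCCN2CCN(c3ccccc3)CC2)Cc2ccccc2)c1` carries the change (phenyl in place of hydrogen on a saturated chain carbon bound to a nitrogen on an aromatic ring); cut one bond further out, the same difference reads methyl to benzyl. Going by the values given here, no measured step touches this position: the single known step, a 9.0-fold lower number from compound 1 to compound 2 (0.95 log units; beyond the scatter), alters the aromatic substituent and says nothing about the group on the nitrogen attached to the aromatic ring. Among the compounds with values here, with no comparable step to lean on, the expectation for compound 3 is a change no larger than the scatter, worded as a 2.0-fold higher number from compound 2 to compound 3 (0.30 log units; within the scatter), and compound 3 is therefore estimated in this assay at 40 nM, within a range from 10 nM to 160 nM.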

Compound 3, inhibition constant: 92.5 nM
Compound 3: middle estimate off by 2.3-fold (0.36 log units), on the low side; the measured number falls inside the stated range.
By their numbers in this assay, from the lowest: compound 2; then compounds 3 and 1 (each within the scatter of the next).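

The group on the nitrogen attached to the aromatic ring, methyl in compounds 1 and 2, proves to matter in this assay: phenyl in place of hydrogen on a saturated chain carbon bound to a nitrogen on an aromatic ring gives a 4.6-fold higher number from compound 2 to compound 3 (0.67 log units; beyond the scatter), a modest weakening that lies beyond the scatter. So the position does respond to this change, and the methyl to benzyl swap costs some inhibition without abolishing it. Nothing available here explains this step.

The compounds shown leave open whether the loss comes with the aromatic ring itself or with any growth at this carbon, which an ethyl or a cyclohexylmethyl group on that nitrogen would separate. They also leave open whether benzyl would act the same way with chloro in place of the hydroxy group.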